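Ethyl to isopropyl on the aryl urea: compound 4

The compounds below may be only part of what the source reports. "The series", "measured", "known", "first", "only" and "open" are said of these compounds alone.

Compound 1 `Cc1ccccc1NC(=O)N[C@H](C)c1ccccc1` gives 99% in an ADME assay on the whole organism with Oryza sativa as the target, tested at 10 uM; a higher number here means a weaker effect of the compound at the concentration tested, a lower number a stronger effect; compound 2 `CCc1ccc(NC(=O)N[C@H](C)c2ccccc2)cc1` gives 44%; compound 3 `CCc1ccc(NC(=O)N[C@@H](C)c2ccccc2)cc1` gives 91%.

On these numbers compound 3 stands second highest of three in this assay. Its nearest neighbour is compound 1, whose value lies within the scatter of it; the furthest is compound 2, whose value lies well apart. Within the data shown here, the only single-point step known is a number 47 percentage points higher from compound 2 to compound 3 (beyond the scatter), which rests on the fact that compounds 2 and 3 differ only in the configuration as drawn and concerns configuration alone.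

Compound 4 `CC(C)c1ccc(NC(=O)N[C@@H](C)c2ccccc2)cc1` differs from compound 3 by methyl in place of hydrogen on a saturated chain carbon bound to an aromatic carbon and a saturated chain carbon. Among the measured compounds shown here, no measured step touches this change: compounds 1 and 2 differ from each other in more than one place, so their values show only that they lie far apart. For the measured compounds named here, the ethyl to isopropyl change therefore carries no measured precedent, and no step beyond the scatter is expected in this assay.

Compound 4 is thus estimated at 85%, with a range from 60% to 100%, meaning an expected step of a number 6 percentage points lower from compound 3 to compound 4 (within the scatter).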

Compound 4, a percentage reported as activity, at one concentration (the size of the read-out at that concentration, not a potency): 86%
Beside the measured number, compound 4's estimate is 1 percentage points below it; the range from low to high includes it.
By their numbers in this assay, from the lowest: compound 2; then compounds 4, 3 and 1 (each within the scatter of the next, the first and the last beyond it).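

In this assay, methyl in place of hydrogen on this saturated chain carbon gives a number 5 percentage points lower from compound 3 to compound 4 (within the scatter). Among these compounds, this is the first measured step at this position, and it shows that going from ethyl to isopropyl, in the configuration drawn for compound 3 and compound 4, leaves the read-out within the scatter. No measurement shown bears on the effect of this change at this carbon.

From the compounds shown here alone, it remains open whether the same methyl would produce so small a step in the configuration of compound 2, which gives 44%. Also open, going by these compounds, is whether a tert-butyl group, a longer chain, an amine or a carboxylic acid at this place would stay within the scatter of compound 3.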